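The source may report more compounds than this note shows. Statements on the series, on what has been measured and on what is new or still open speak of the compounds shown alone.

Measured so far:
compound 1, `CNC(=O)c1ccccc1-c1ccc(CNc2nccc(C)c2NC(=O)CC(F)(F)F)cc1`: 1 h
compound 2, `COC(=O)c1ccccc1-c1ccc([C@@H](C)Nc2nccc(C)c2NC(=O)CC#N)cc1`: 0.2 h

In an ADME assay (Rattus norvegicus, strain Sprague Dawley) for metabolic stability (on this read-out higher numbers stand for a longer-lived compound and lower numbers for a shorter-lived compound), compound 1 stands highest of the two numbers; compound 2 gives 0.2 h, a gap beyond the usual scatter. For the measured compounds named here, no measured pair differs in only one place, so no single-change step is available to guide the next compound. Compound 3, `CNC(=O)c1ccccc1-c1ccc([C@@H](C)Nc2nccc(C)c2NC(=O)CC(F)(F)F)cc1`, carries methyl in place of hydrogen on a saturated chain carbon bound to an aromatic carbon and a nitrogen on an aromatic ring relative to compound 1. For compound 3 the expected step is a 1.3-fold lower number from compound 1 to compound 3 (0.10 log units; within the scatter), small and of uncertain direction, likely within the scatter. The estimate for compound 3 in this assay is 0.8 h, within 0.3 h to 2 h.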

Compound 3, half-life: 0.5 h
Compound 3: middle estimate off by 1.6-fold (0.20 log units), on the high side; measured number inside the range.
By their numbers in this assay, from the lowest: compound 2; then compounds 3 and 1 (each within the scatter of the next).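

In this assay, methyl in place of hydrogen on a saturated chain carbon bound to an aromatic carbon and a nitrogen on an aromatic ring gives a 2.0-fold lower number from compound 1 to compound 3 (0.30 log units; within the scatter). For the compounds shown here, this is the first single-change reading, and at this position it does not separate methyl from hydrogen. Nothing available explains this result. Open, going by these compounds, is whether ethyl or hydroxymethyl on this same carbon, or the opposite stereoisomer of the methyl compound, would give a step beyond the scatter.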